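The compounds below may be only part of what the source reports. "The series", "measured", "known", "first", "only" and "open" are said of these compounds alone.

Compound 1 `CN(C(=O)NC(=O)c1c(F)cccc1F)c1nc(C(F)(F)F)c(C(=O)N/N=C/c2cccc(C(F)(F)F)c2)s1`, compound 2 `Cc1nc(N(C)C(=O)NC(=O)c2c(F)cccc2F)sc1C(=O)N/N=C/c1cccc(C(F)(F)F)c1` and compound 3 `CN(C(=O)NC(=O)c1ccc(Cl)c(Cl)c1)c1nc(C(F)(F)F)c(C(=O)N/N=C/c2cccc([N+](=O)[O-])c2)s1` share one core and have been measured in a functional assay on HepG2 cells (Homo sapiens) for inhibition, read by MTT assay, with a stated time of 72 h; on this read-out lower numbers stand for stronger inhibition and higher numbers for weaker inhibition. Compound 1 gives 27.9 ug/mL, compound 2 gives 31.6 ug/mL and compound 3 gives 7.98 ug/mL; compound 2 stands close to compound 1 and clearly apart from compound 3. Among the measured compounds shown here, the single one-place step, a 1.1-fold higher number from compound 1 to compound 2 (0.05 log units; within the scatter), concerns the core and not the carbon with a double bond to nitrogen. Compound 4 `COc1cc(/C=N/NC(=O)c2sc(N(C)C(=O)NC(=O)c3c(F)cccc3F)nc2C)cc(OC)c1OC` differs from compound 2 by 3,4,5-trimethoxyphenyl in place of 3-(trifluoromethyl)phenyl on a carbon with a double bond to nitrogen. For the measured compounds named here, no measured step touches this position; compound 3 carries another group there but also another acyl part, so its value is no guide. Compound 4 is therefore expected near 28 ug/mL in this assay, between 8 ug/mL and 90 ug/mL, meaning a 1.1-fold lower number from compound 2 to compound 4 (0.05 log units; within the scatter).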

Compound 4, half-maximal inhibitory concentration: > 100 ug/mL
Compound 4: no number, only a limit; the forecaster's own chance of this, stated with the estimate: 10%; middle value at least 3.5-fold (0.55 log units) from the limit.
By their numbers in this assay, from the lowest: compound 3; then compounds 1 and 2 (each within the scatter of the next). At a limit, above all of these: compound 4.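

In this assay, the group on a carbon with a double bond to nitrogen proves able to weaken inhibition, with 3,4,5-trimethoxyphenyl in place of 3-(trifluoromethyl)phenyl giving an at least 3.1-fold higher number from compound 2 to compound 4 (0.50 log units; beyond the scatter). No earlier one-place step showed a change beyond the scatter, so this position is the first shown to matter in the series. For compound 4, > 100 ug/mL is a limit and not a number: the limit of > 100 ug/mL in this assay, at which 1 of the 4 values shown sits.

Whether the whole 3,4,5-trimethoxyphenyl group or a single methoxy group accounts for this step stays open. So does the effect of a phenyl carrying an amine or a carboxylic acid at this position.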